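This account rests on a few compounds, and the source may have more. Where it says the series, first, only, none or still open, it means among the compounds named here.

Measured so far:
- compound 1 `C=CCN(CCC)Cc1c(C(F)(F)F)nc2n(-c3c(C)cc(C)cc3C)c(Cl)cn12` gives 4.5 nM in an assay on cells for displacement of a labelled ligand from corticotropin-releasing factor receptor 1 (Homo sapiens), with a stated time of 100 min; on this read-out lower numbers stand for stronger inhibition and higher numbers for weaker inhibition
- compound 2 `CCN(Cc1ccccc1)Cc1c(C(F)(F)F)nc2n(-c3c(C)cc(C)cc3C)c(Cl)cn12` gives 350 nM in this assay

Among the compounds with values here, compound 2 stands at the highest of the two numbers in this assay; its nearest neighbour is compound 1, and the change between them is a 78-fold higher number from compound 1 to compound 2 (1.89 log units; beyond the scatter), the one step recorded here, and a large one.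

Compound 3 `Cc1cc(C)c(-n2c(Cl)cn3c(CN4CCCC4c4ccccc4)c(C(F)(F)F)nc23)c(C)c1` has not been measured. It differs from compound 2 by 2-phenylpyrrolidin-1-yl in place of benzyl(ethyl)amino on a saturated chain carbon bound to an aromatic carbon. Within the data shown here, no measured step covers this particular change. Among the measured compounds shown here, the only step on record, a 78-fold higher number from compound 1 to compound 2 (1.89 log units; beyond the scatter), shows that a change of the groups on the amine nitrogen at this position can move the number a long way, but it says nothing about whether closing those groups into a ring helps or hurts. In this assay compound 3 is therefore expected to land near compound 2, with a wide range on either side, and the step from compound 2 is estimated as a 1.8-fold lower number from compound 2 to compound 3 (0.24 log units; within the scatter). The expected value for compound 3 in this assay is 200 nM, with a likely range from 30 nM to 1500 nM.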

Compound 3, inhibition constant: > 7000 nM
Compound 3: no number, only a limit; the forecaster's own chance of this, stated with the estimate: 5%; middle value at least 35-fold (1.54 log units) from the limit.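

For compound 3, the result in this assay is a limit of the assay and not a number: the limit of > 7000 nM in this assay, at which 1 of the 3 values shown sits. Even so, the limit gives the direction of the change, which the earlier compounds did not: with 2-phenylpyrrolidin-1-yl in place of benzyl(ethyl)amino on a saturated chain carbon bound to an aromatic carbon, there is an at least 20-fold higher number from compound 2 to compound 3 (1.30 log units; beyond the scatter), so closing the groups on the amine nitrogen into this ring, with a six-membered aromatic ring of carbon only still present in the group, does not bring back any of the strength lost on the earlier step. Within the data shown here, measured against the allyl(propyl)amino group of the first compound, the change is an at least 1500-fold higher number from compound 1 to compound 3 (3.19 log units; beyond the scatter), which makes this position more sensitive to the amine group than the one earlier step alone could show, with both amine groups that carry an aromatic ring giving higher numbers than the allyl(propyl)amino group.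

The compounds shown leave open whether the five-membered ring or the phenyl group on it accounts for this loss, a question that a plain pyrrolidin-1-yl group, a piperidin-1-yl group or a diallylamino group at this place would address. As far as these compounds go, they also leave open how far the true number of compound 3 lies beyond its limit, so the full size of both steps remains unknown.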